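The source may hold more compounds than are shown below. What is called first, only, known or untested is meant among the compounds shown, and "the series" means these compounds.

Measured so far:
compound 1 `CCc1cc(C(=O)N2CCCCc3ccccc32)ccc1CNC(=O)Nc1c(F)cccc1F`: 10 nM
compound 2 `Cc1cc(C(=O)N2CCCCc3ccccc32)ccc1CNC(=O)NCC(=O)OC(C)(C)C`: 120 nM

Both were run in a functional assay on HEK293 cells for agonist activity at Vasopressin V2 receptor (Homo sapiens), read by a luciferase reporter and cAMP accumulation; a higher number here means that more compound is needed for the effect, a lower number that less compound is needed. Among the compounds with values here, compound 2 gives the highest of the two numbers, and compound 1 the lower one, a gap beyond the scatter; no single-point step between them is counted here.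

Compound 3 `Cc1cc(C(=O)N2CCCCc3ccccc32)ccc1CNC(=O)N1CCC[C@@H]1C(=O)N(C)C` is not yet measured. It differs from compound 2 in one place: 2-(dimethylcarbamoyl)pyrrolidin-1-yl in place of ((tert-butoxycarbonyl)methyl)amino on a carbonyl carbon. Within the data shown here, no measured step of this kind exists in the set, so the expectation rests on compound 2 alone. The change is expected to give no step beyond the scatter, perhaps a slight lowering, so that a 1.5-fold lower number from compound 2 to compound 3 (0.18 log units; within the scatter) is the estimated step. Compound 3 is therefore expected at 80 nM, in a range from 15 nM to 400 nM.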

Compound 3, half-maximal effective concentration: 380 nM
Compound 3: the middle estimate sits 4.8-fold (0.68 log units) below what was measured; the measured number falls inside the stated range.
By their numbers in this assay, from the lowest: compound 1; then compound 2; then compound 3.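

At this carbonyl carbon the position responds to the change: 2-(dimethylcarbamoyl)pyrrolidin-1-yl in place of ((tert-butoxycarbonyl)methyl)amino gives a 3.2-fold higher number from compound 2 to compound 3 (0.50 log units; beyond the scatter) in this assay. The exchange adds a ring and a defined stereocentre and removes the hydrogen-bond donor, all in one step, so these features cannot be separated here. No available measurement explains the step.

Still open, as far as these compounds go, is whether a plain pyrrolidin-1-yl, without the dimethylcarbamoyl group, would retain the number of compound 2 or that of compound 3. The opposite configuration at the stereocentre and a carboxylic acid in place of the tert-butyl ester also remain untested in the compounds shown here.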